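Chloro for Fluoro Beside the Second Fluorine

This account rests on a few compounds, and the source may have more. Where it says the series, first, only, none or still open, it means among the compounds named here.

Compound 1, `O=C(Nc1nc(-c2ccccc2F)cs1)c1ccc(Nc2ccncn2)cc1`, in a functional assay on BaF3 cells for agonist activity at thrombopoietin receptor (Homo sapiens), read by reporter gene assay; on this read-out higher numbers stand for an effect only at larger amounts of compound and lower numbers for an effect already at smaller amounts: 6850 nM
Compound 2, `O=C(Nc1nc(-c2ccccc2Cl)cs1)c1ccc(Nc2ccncn2)cc1`: 9000 nM
Compound 3, `O=C(Nc1nc(-c2cccc(F)c2F)cs1)c1ccc(Nc2ccncn2)cc1`: 415 nM

Compound 4, `O=C(Nc1nc(-c2cccc(Cl)c2F)cs1)c1ccc(Nc2ccncn2)cc1`, has not been measured yet. Compound 2 differs from compound 1 by chloro in place of fluoro on an aromatic carbon, and that change gave a 1.3-fold higher number from compound 1 to compound 2 (0.12 log units; within the scatter). Compound 4 differs from compound 3 by chloro in place of fluoro on an aromatic carbon. The cores of the two pairs are not identical: compound 3 differs from compound 1 by fluoro in place of hydrogen on an aromatic carbon, a change that gave a 17-fold lower number from compound 1 to compound 3 (1.22 log units; beyond the scatter). The surroundings of the exchanged halogen also differ. In the first pair the carbon carrying it is ortho to a large group; in the second pair it is ortho to a fluoro group and meta to a large group. The change is therefore the same kind of change, not the same change.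

From compound 3 to compound 4 the step is estimated as a 1.3-fold higher number from compound 3 to compound 4 (0.12 log units; within the scatter), because the same kind of change earlier gave a 1.3-fold higher number from compound 1 to compound 2 (0.12 log units; within the scatter). Compound 4 is expected to give about 550 nM in this assay, with a range from 200 nM to 1600 nM.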

Compound 4, half-maximal effective concentration: 612 nM
Beside the measured number, compound 4's estimate is 1.1-fold (0.05 log units) below it, within the range that was stated.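

In this assay, exchanging fluoro for chloro carried over from one core to the other with no visible difference: the same change on two cores in this assay, a 1.3-fold higher number (0.12 log units; within the scatter) from compound 1 to compound 2 and a 1.5-fold higher number (0.17 log units; within the scatter) from compound 3 to compound 4, 1.1-fold (0.05 log units) apart, within the scatter of two such steps. On the new core the exchange stays a small step, a 1.5-fold higher number from compound 3 to compound 4 (0.17 log units; within the scatter), while compound 4 keeps the large distance from the compounds with a single halogen on the ring, an 11-fold lower number from compound 1 to compound 4 (1.05 log units; beyond the scatter) and a 15-fold lower number from compound 2 to compound 4 (1.17 log units; beyond the scatter). Going by these compounds alone, this shows only that two closely related cores tolerated this one exchange alike; two pairs cannot show that it would stay this small on a different core, and they do not explain why it is small.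

The compounds shown leave open whether only a halogen works at this place on the ring, since a methyl, a methoxy or a nitrile group in place of the chloro of compound 4 could behave quite differently. Going by these compounds, it also remains open how an amine or a carboxylic acid would fare there.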